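A few compounds are considered here, and "the series" means these few. Any claim that something is new, unique, unknown or untested is made for them only; others in the source may bear on it.

Measured in a functional assay on MDA-MB-231 cells (Homo sapiens) for cytotoxicity, read by MTT assay; on this read-out lower numbers stand for stronger inhibition and higher numbers for weaker inhibition: compound 1 `CCOc1c(Br)cc(/C=C2\CCC/C(=C\c3cccc([N+](=O)[O-])c3)C2=O)cc1OC` gives 19.3 ug/mL, and compound 3 `COc1cc(/C=C2\CCC/C(=C\c3ccc([N+](=O)[O-])cc3)C2=O)cc(Br)c1OC` gives 8.71 ug/mL. Compound 2 `COc1cc(/C=C2\CCC/C(=C\c3ccc([N+](=O)[O-])cc3)C2=O)cc(Br)c1O` gives > 100 ug/mL, which is a limit of the assay and not a number, namely (the limit of > 100 ug/mL in this assay, at which 1 of the 3 values shown sits).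

Compound 3 therefore holds the lowest of the two numbers, with compound 1 the nearest and beyond the scatter. Compound 4 `CCOc1c(Br)cc(/C=C2\CCC/C(=C\c3ccc([N+](=O)[O-])cc3)C2=O)cc1OC` differs from compound 3 by methyl in place of hydrogen on a saturated chain carbon bound to an oxygen on an aromatic ring. For the measured compounds named here, the only measured step on this oxygen is an at least 11-fold lower number from compound 2 to compound 3 (1.05 log units; beyond the scatter), a large one, but it concerns hydrogen to methyl rather than methyl to ethyl. Compound 1 already carries an ethoxy there and gives 19.3 ug/mL, though its nitro group sits differently. The step is expected to be a 1.3-fold higher number from compound 3 to compound 4 (0.10 log units; within the scatter), within the scatter. Compound 4 is estimated at 11 ug/mL, between 4.5 ug/mL and 27 ug/mL.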

Compound 4, half-maximal inhibitory concentration: 34.7 ug/mL
Compound 4: the middle estimate sits 3.2-fold (0.50 log units) below what was measured; measured number outside the range, above it.
By their numbers in this assay, from the lowest: compound 3; then compounds 1 and 4 (each within the scatter of the next). At a limit, above all of these: compound 2.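

At this oxygen, capping the hydrogen is not the whole story: methoxy to ethoxy gives a 4.0-fold higher number from compound 3 to compound 4 (0.60 log units; beyond the scatter) and the ethyl compound still shows an at least 2.8-fold lower number from compound 2 to compound 4 (0.45 log units; beyond the scatter) so ethoxy keeps part of the gain over the free hydroxyl. That second step rests on a limit of the assay for compound 2: the limit of > 100 ug/mL in this assay, at which 1 of the 4 values shown sits. With ethoxy on both, 4-nitrophenyl in place of 3-nitrophenyl gives a 1.8-fold higher number from compound 1 to compound 4 (0.25 log units; within the scatter) so these two nitro isomers cannot be told apart here. The compounds shown leave open whether a longer chain such as propyl on this oxygen would raise the number further, and how a chain ending in an amine would behave there.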